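The source may hold more compounds than are shown below. What is called first, only, known or untested is meant among the compounds shown, and "the series" means these compounds.

Measured so far:
Compound 1 `COc1ccccc1Oc1ccc2c(NCCCNCc3ccco3)ccnc2c1` — 14500 nM
Compound 2 `c1ccc(Oc2ccc3c(NCCCNCc4ccco4)ccnc3c2)cc1` — 14500 nM
Compound 3 `Cc1cc(C)cc(Cc2ccc3c(NCCCNCc4ccco4)ccnc3c2)c1` — 4200 nM

In a physicochemical assay for solubility, with a stated time of 18 h, at pH 7.4 (on this read-out higher numbers stand for higher solubility and lower numbers for lower solubility), compound 2 stands level with compound 1, the two together the highest of the three, with compound 3 as the furthest, a 3.5-fold lower number from compound 2 to compound 3 (0.54 log units; beyond the scatter). Compound 4 `COc1cccc(CNCCCNc2ccnc3cc(Oc4ccccc4)ccc23)c1O` differs from compound 2 at the other end of the molecule: 2-hydroxy-3-methoxyphenyl in place of furan-2-yl on a saturated chain carbon bound to an amine nitrogen. Going by the values given here, none of the measured steps touches this part; no change at the digits printed from compound 1 to compound 2 (within the scatter) and a 3.5-fold lower number from compound 2 to compound 3 (0.54 log units; beyond the scatter) both altered the group on the aromatic carbon of the core. They show that one group swap there left the number unchanged while another moved it modestly, so a modest shift in either direction is plausible, and no direction is supported by a measured step. Compound 4 is therefore expected to give 10000 nM, between 3000 nM and 30000 nM, meaning an expected 1.5-fold lower number from compound 2 to compound 4 (0.16 log units; within the scatter).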

Compound 4, solubility: 14500 nM
For compound 4 the middle estimate is 1.5-fold (0.16 log units) below the measured one, within the range that was stated.
By their numbers in this assay, from the lowest: compound 3; then compounds 1, 2 and 4 (each within the scatter of the next).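

Going by these compounds alone, this is the first measured change at the amine end of the molecule, away from the aromatic carbon of the core. In this assay, a group of 9 heavy atoms with 1 hydrogen-bond donor replaces one of 5 heavy atoms with 0 donors, and the step reads no change at the digits printed from compound 2 to compound 4 (within the scatter), so this position tolerated this swap without a shift beyond the scatter. Nothing given here explains that result.

Still open, as far as these compounds go, is whether a carboxylic acid or a dimethylamino group at this place would also leave the number level, and whether a longer chain linking the two amine nitrogens would do the same.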